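From a Measured Limit to an Untested Longer Side Chain

A few compounds are considered here, and "the series" means these few. Any claim that something is new, unique, unknown or untested is made for them only; others in the source may bear on it.

Compound 1 `CC(C)N/C(=N\c1ncc[nH]1)Nc1ccc(Cl)c(Cl)c1` and compound 2 `CC(C)C(=O)N/C(=N/c1nccn1C(C)C)Nc1ccc(Cl)c(Cl)c1` share a core and were studied in an in vitro ADME assay on microsomes from liver (Mus musculus) for metabolic stability, read by LC-MS, tested at 1 uM; a lower number here means that the compound disappears faster, a higher number that the compound lasts longer. In this assay compound 1 gives 0.627 h. From the compounds shown here alone, for compound 2 this assay reports only a limit, > 1 h, so its exact position is unknown; it stands at the limit of > 1 h in this assay, at which 1 of the 2 values shown sits. Compound 3 `CCC(CC)C(=O)N/C(=N/c1nccn1C(C)C)Nc1ccc(Cl)c(Cl)c1` is not yet measured and differs from compound 2 in one place: pentan-3-yl in place of isopropyl on a carbonyl carbon. Among the compounds with values here, no measured pair shows this change, so no step beyond the usual scatter is expected in either direction. Compound 3 is therefore estimated at 1.2 h, between 0.5 h and 3 h, an expected step that the limit leaves unreadable from compound 2 to compound 3.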

Compound 3, half-life: > 1 h
Compound 3 ended at the assay's limit; the forecaster's own chance of this, stated with the estimate: 50%; the middle value lies beyond the limit too.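

Compound 2 and compound 3 both end at a limit rather than a number, so no step between them can be read in this assay: the limit of > 1 h in this assay, at which 2 of the 3 values shown sit.

Left open is how long each compound actually lasts, and whether pentan-3-yl in place of isopropyl changes that at all.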